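This account rests on a few compounds, and the source may have more. Where it says the series, first, only, none or still open, it means among the compounds named here.

Compound 1 `CC(C)Cn1c(SCc2ccccc2)nc(N)cc1=O` gives 83300 nM in a functional assay on A549 cells (Homo sapiens) for antiproliferative activity, read by MTT assay, with a stated time of 72 h; on this read-out higher numbers stand for weaker inhibition of growth and lower numbers for stronger inhibition of growth.
Compound 2 `CC(=O)Nc1cc(=O)n(CC(C)C)c(SCc2ccccc2)n1` gives 46400 nM in this assay.
Compound 3 `Cc1ccc2nc(-c3ccc(N)cc3)cn2c1` gives > 100000 nM in this assay, and this is a limit of the measurement rather than a number.

Compound 3 therefore sits at the limit of > 100000 nM in this assay, at which 1 of the 3 values shown sits, and no actual number is known for it. Compound 4 `Cc1ccc2nc(-c3ccc(NCc4ccccc4)cc3)cn2c1` differs from compound 3 in one place: benzyl in place of hydrogen on a nitrogen on an aromatic ring. Among the compounds with values here, the only measured step that touches a substituent on a ring nitrogen is a 1.8-fold lower number from compound 1 to compound 2 (0.25 log units; within the scatter); it lies on a different core and brings in an acetyl rather than a benzyl, so it bears only loosely on the present change. Taken as the sole guide, it points to a step of modest size at most, and the fact that compound 3 starts from a limit leaves the direction open. Compound 4 is thus expected to give about 80000 nM in this assay, within a range from 20000 nM to 300000 nM. The expected step is an at least 1.2-fold lower number from compound 3 to compound 4 (0.09 log units; that floor lies within the scatter), and a reading that is again only a limit would not be surprising.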

Compound 4, concentration for 50% growth inhibition: 56100 nM
The estimate for compound 4 lay 1.4-fold (0.15 log units) above the measured number; the range from low to high includes it.
By their numbers in this assay, from the lowest: compounds 2, 4 and 1 (each within the scatter of the next). At a limit, above all of these: compound 3.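

Within the data shown here, on the nitrogen on an aromatic ring, amino to benzylamino gives the first actual number on the core of compound 3, with compound 4 at 56100 nM in this assay. The change reads as an at least 1.7-fold lower number from compound 3 to compound 4 (0.25 log units; that floor lies within the scatter), so the benzyl is at least compatible with a measurable reading at this position. That step is only a floor and its true size cannot be read, because the value of compound 3 is a limit and not a number: the limit of > 100000 nM in this assay, at which 1 of the 4 values shown sits.

Open, going by these compounds, is whether a methyl or a longer chain on that nitrogen would give a reading like that of compound 4, which would show whether the ring of the benzyl matters at all. Also open, on these data alone, is whether an amine or a carboxylic acid on the benzyl ring would change the reading beyond the scatter.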